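Hydrogen for Methyl on the Aromatic Nitrogen: Cytotoxicity Outlook

This account rests on a few compounds, and the source may have more. Where it says the series, first, only, none or still open, it means among the compounds named here.

The series rests on three measured compounds. Compound 1 `Cn1cc([N+](=O)[O-])cc1C(=O)NNC(=S)Nc1ccc(Cl)cc1` gives, in an ADME assay on Vero cells (Chlorocebus sabaeus) for cytotoxicity, read by MTT assay, with a stated time of 72 h (on this read-out lower numbers stand for stronger inhibition and higher numbers for weaker inhibition), a value of 210000 nM. Compound 2 `Cn1cc([N+](=O)[O-])cc1C(=O)NNC(=S)NCc1ccccc1` gives 239000 nM in this assay, and compound 3 `Cn1cc([N+](=O)[O-])cc1C(=O)NNC(=S)NC1CCCCC1` gives 352000 nM. Compound 1 holds the lowest of the three numbers, but the spread is small: the step is a 1.1-fold higher number from compound 1 to compound 2 (0.06 log units; within the scatter) and a 1.7-fold higher number from compound 1 to compound 3 (0.22 log units; within the scatter), and between the other two it is a 1.5-fold higher number from compound 2 to compound 3 (0.17 log units; within the scatter). All three steps vary only the group on the amide-type nitrogen, and none of them reaches beyond the scatter.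

Compound 4 `O=C(NNC(=S)Nc1ccc(Cl)cc1)c1cc([N+](=O)[O-])c[nH]1` differs from compound 1 at a different place: hydrogen in place of methyl on an aromatic nitrogen. Going by the values given here, no measured step touches this aromatic nitrogen, so nothing in the data speaks directly to it. Among the compounds with values here, the only guidance is that the three substituent changes elsewhere left this assay essentially flat, which gives no basis for predicting a shift in either direction. The step is therefore expected to be no change at the digits printed from compound 1 to compound 4 (within the scatter), within the scatter. The estimate for compound 4 in this assay is 210000 nM, with a range from 110000 nM to 400000 nM.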

Compound 4, half-maximal inhibitory concentration: 191000 nM
Compound 4: middle estimate off by 1.1-fold (0.04 log units), on the high side; low and high end bracket the measured number.
By their numbers in this assay, from the lowest: compounds 4, 1, 2 and 3 (each within the scatter of the next).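

Going by these compounds alone, with hydrogen in place of methyl on the aromatic nitrogen, this assay gives a 1.1-fold lower number from compound 1 to compound 4 (0.04 log units; within the scatter) and so places this site, on a five-membered aromatic ring and two ring bonds from the ring atom that bears a nitro group, under direct measurement for the first time. The earlier steps shown here changed only the group on the amide-type nitrogen, whereas this pair shows that the read-out also stays within the scatter when one carbon leaves a second place in the molecule, though that finding rests on a single pair carrying the 4-chlorophenyl group. No measurement offered here accounts for this result.

The compounds shown leave open whether an ethyl group, a longer chain, or a chain ending in an amine or a carboxylic acid on this aromatic nitrogen would also stay within the scatter of compound 1. They also leave open whether hydrogen in place of methyl would give a similar result alongside the benzyl group of compound 2 or the cyclohexyl group of compound 3.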